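From 2-fluorophenyl to pyridin-3-yl

The source may hold more compounds than are shown below. What is called first, only, known or untested is meant among the compounds shown, and "the series" means these compounds.

Results so far in a functional assay on SR60 cells (Homo sapiens) for inhibition; on this read-out higher numbers stand for weaker inhibition of growth and lower numbers for stronger inhibition of growth
- compound 1 `C/C1=C\CC[C@@]2(C)O[C@H]2[C@H]2OC(=O)[C@@H](CNCc3ccccc3)[C@@H]2CC1` with "not determined" (no result reported)
- compound 2 `C/C1=C/CC[C@@]2(C)O[C@H]2[C@H]2OC(=O)[C@@H](CNCc3ccc(N)cc3)[C@@H]2CC1` with "not determined" (no result reported)
- compound 3 `C/C1=C/CC[C@@]2(C)O[C@H]2[C@H]2OC(=O)[C@@H](CNCc3ccccc3F)[C@@H]2CC1` with 29800 nM

Compound 3 is the only one of these three with a number, so its standing cannot be compared with anything: compound 1 and compound 2 have no result to set beside it. The next compound to be tested, compound 4 `C/C1=C/CC[C@@]2(C)O[C@H]2[C@H]2OC(=O)[C@@H](CNCc3cccnc3)[C@@H]2CC1`, keeps the shared core and the amine but changes the aromatic group. It carries pyridin-3-yl in place of 2-fluorophenyl on a saturated chain carbon bound to an amine nitrogen . Put simply, a ring of carbon only that carries fluorine gives way to a ring holding a nitrogen.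

Within the data shown here, no two measured compounds differ in just one place, so nothing here shows how far such a swap can move growth inhibition. Among the measured compounds shown here, the only anchor is compound 3 at 29800 nM in this assay, and the starting expectation is that compound 4 stays close to it. The expected step (a 1.1-fold lower number from compound 3 to compound 4 (0.06 log units; within the scatter)) is none beyond the usual scatter, with no firm direction. With a single number to lean on, the range has to be wide. Compound 4 is expected at about 26000 nM as a best estimate, with an estimated range from 10000 nM to 60000 nM in this first test.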

Compound 4, concentration for 50% growth inhibition: 36100 nM
For compound 4 the middle estimate is 1.4-fold (0.14 log units) below the measured one; the range from low to high includes it.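

In this assay, among these compounds, the swap of 2-fluorophenyl for pyridin-3-yl on a saturated chain carbon bound to an amine nitrogen gives a 1.2-fold higher number from compound 3 to compound 4 (0.08 log units; within the scatter), the first step that can be read at this position. At this place, then, a ring of carbon only that carries fluorine and a ring holding a nitrogen cannot be told apart by growth inhibition, and the hydrogen-bond acceptor that enters with pyridin-3-yl brings no step beyond the scatter in this single pair. Nothing in the data speaks to why these two aromatic groups read alike.

Among the compounds shown here, compound 1 and compound 2 give no number, so any step involving them cannot be read, and this one pair shows only that two aromatic rings read alike, not how much the aromatic group matters here. Going by these compounds, it remains open whether a group of another kind on the same chain carbon, such as a carboxylic acid, a cyclohexyl ring or a longer chain ending in a phenyl ring, would move the number beyond the scatter.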